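The source may report more compounds than this note shows. Statements on the series, on what has been measured and on what is new or still open speak of the compounds shown alone.

Among the compounds with values here, in a functional assay on CCRF-CEM cells (Homo sapiens) for antiproliferative activity, with a stated time of 72 h (a higher number here means a weaker inhibitor, a lower number a stronger inhibitor), compound 2 `OC[C@H]1O[C@@H](n2cnc3c(NCc4cccc(Br)c4)ncnc32)[C@H](O)[C@@H]1O` gives 5000 nM as the lowest number so far, which makes it the strongest inhibitor among the measured compounds. Compound 1 `OC[C@H]1O[C@@H](n2cnc3c(NCc4ccc(Cl)cc4)ncnc32)[C@H](O)[C@@H]1O` gives 10200 nM and sits closest to it. Compound 3 `Cc1ccc(CNc2ncnc3c2ncn3[C@@H]2O[C@H](CO)[C@@H](O)[C@H]2O)cc1` reads > 166000 nM and this is a limit of the assay, not a number.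

Compound 4 `COc1ccccc1CNc1ncnc2c1ncn2[C@@H]1O[C@H](CO)[C@@H](O)[C@H]1O` has not yet been measured. It differs from compound 2 in one place, on a saturated chain carbon bound to a nitrogen on an aromatic ring, where 2-methoxyphenyl stands in place of 3-bromophenyl: 2-methoxyphenyl in place of 3-bromophenyl on a saturated chain carbon bound to a nitrogen on an aromatic ring.

Two measured steps change this same place. The first, a 2.0-fold lower number from compound 1 to compound 2 (0.31 log units; beyond the scatter), is modest. The second, an at least 33-fold higher number from compound 2 to compound 3 (1.52 log units; beyond the scatter), is large. Swapping one substituted phenyl for another can therefore change little or a great deal, and no measured compound carries a methoxy group. Compound 2 has the lowest number of the set at 5000 nM and so a higher number is the likelier direction for compound 4, by a moderate to large step. The expected change is a 6.0-fold higher number from compound 2 to compound 4 (0.78 log units; beyond the scatter) and this remains an estimate. For compound 4 the estimated value is 30000 nM with an expected range from 6000 nM to 150000 nM in this assay.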

Compound 4, half-maximal inhibitory concentration: 3200 nM
Compound 4: the middle estimate sits 9.4-fold (0.97 log units) above what was measured; the measured number lies below the stated range.
By their numbers in this assay, from the lowest: compounds 4 and 2 (each within the scatter of the next); then compound 1. At a limit, above all of these: compound 3.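

Within the data shown here, the earlier compounds left room for the idea that this place needs a halogen on the phenyl ring, since the only compound without one, compound 3, sat far from the others, but compound 4 carries no halogen and the change from 3-bromophenyl to 2-methoxyphenyl gives a 1.6-fold lower number from compound 2 to compound 4 (0.19 log units; within the scatter), so the two cannot be told apart here. Compared with 4-chlorophenyl, the same group gives a 3.2-fold lower number from compound 1 to compound 4 (0.50 log units; beyond the scatter), and compared with 4-methylphenyl, it gives an at least 51-fold lower number from compound 3 to compound 4 (1.71 log units; beyond the scatter). That last step rests on compound 3, whose reading is a limit and not a number: the limit of > 166000 nM in this assay, at which 1 of the 4 values shown sits.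

The compounds shown change the substituent and its location on the phenyl ring together, so 4-methoxyphenyl and 2-methylphenyl are the groups that could tell whether the methoxy group or its location goes with the reading of compound 4. Going by these compounds, how a longer chain carrying the phenyl ring, or a carboxylic acid on that ring, would read at this place also stays open.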